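The compounds below may be only part of what the source reports. "The series", "measured", "known", "first", "only" and "open" are said of these compounds alone.

Measured so far:
- compound 1 `O=C(CC(=O)c1cc(Cl)ccc1O)c1cc2ccccc2s1`: 8.44 ug/mL
- compound 2 `O=C(CC(=O)c1cc(Br)ccc1O)c1cc2ccccc2s1`: 18.3 ug/mL

Within the data shown here, in an ADME assay on PANC-1 cells (Homo sapiens) for inhibition, read by MTT assay, with a stated time of 90 h (a higher number here means a weaker inhibitor of growth, a lower number a stronger inhibitor of growth), compound 2 gives 18.3 ug/mL, the higher of the two numbers; compound 1 gives 8.44 ug/mL, the only step being a 2.2-fold higher number from compound 1 to compound 2 (0.34 log units; beyond the scatter). Compound 3 `Cc1ccc(O)c(C(=O)CC(=O)c2cc3ccccc3s2)c1` is not yet measured. It differs from compound 2 by methyl in place of bromo on an aromatic carbon. Among the measured compounds shown here, the one measured step swaps one halogen for another and so bears only loosely on a halogen-to-methyl change; it shows that a single change at this carbon moves the number modestly. A modest step in either direction, or none beyond the scatter, is therefore expected, a 1.3-fold lower number from compound 2 to compound 3 (0.12 log units; within the scatter). Compound 3 is estimated at 14 ug/mL, within 6 ug/mL to 35 ug/mL.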

Compound 3, concentration for 50% growth inhibition: 15.8 ug/mL
The estimate for compound 3 lay 1.1-fold (0.05 log units) below the measured number, within the range that was stated.
By their numbers in this assay, from the lowest: compounds 1, 3 and 2 (each within the scatter of the next, the first and the last beyond it).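

Methyl in place of bromo, para to a hydroxy group, gives a 1.2-fold lower number from compound 2 to compound 3 (0.06 log units; within the scatter) in this assay and so does not separate from bromo. Methyl in place of chloro gives a 1.9-fold higher number from compound 1 to compound 3 (0.27 log units; within the scatter) in the same read-out, so compound 3 lies within the scatter of both halogen compounds, although those two lie beyond it from each other. No measurement shown bears on the reason for these numbers.

Going by these compounds, whether an amine, a carboxylic acid or a longer chain at this carbon would stay in this range remains open. On these data alone, the effect of the same changes on any other part of the core also remains open.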